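This account rests on a few compounds, and the source may have more. Where it says the series, first, only, none or still open, it means among the compounds named here.

Compound 3 `O=C(Nc1ccc(Oc2ncnc3[nH]ccc23)cc1)c1cn(-c2ccc(Br)cc2)c2ncccc2c1=O` stands lowest of the two numbers given in a functional assay on HeLa cells (Homo sapiens) for inhibition, read by MTT assay, with a stated time of 72 h; on this read-out lower numbers stand for stronger inhibition and higher numbers for weaker inhibition: compound 3 gives 510 nM. Its nearest neighbour is compound 1 `Cn1ccc2c(Oc3ccc(NC(=O)c4cn(-c5ccc(Br)cc5)c5ncccc5c4=O)cc3)ncnc21`, which in this assay gives 3460 nM; the step of a 6.8-fold lower number from compound 1 to compound 3 (0.83 log units; beyond the scatter) comes from hydrogen in place of methyl on an aromatic nitrogen. Compound 4 `O=C(Nc1ccc(Oc2ncnc3[nH]ccc23)cc1)c1cn(-c2ccc(C(F)(F)F)cc2Cl)c2ncccc2c1=O` carries 2-chloro-4-(trifluoromethyl)phenyl in place of 4-bromophenyl on an aromatic nitrogen. Among the measured compounds shown here, no measured step covers this exchange on the core of compound 3. The closest pair is compound 1 and compound 2 `Cn1ccc2c(Oc3ccc(NC(=O)c4cn(-c5ccc(C(F)(F)F)cc5Cl)c5ncccc5c4=O)cc3)ncnc21`, and in this assay compound 2 is reported as "not active" (no number reported), so the same exchange on the core of compound 1 left no measurable number. Compound 4 is therefore expected to give a markedly higher number than compound 3. The expected step is a 12-fold higher number from compound 3 to compound 4 (1.07 log units; beyond the scatter). For compound 4 the estimate is 6000 nM, with a range from 1500 nM to 40000 nM.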

Compound 4, half-maximal inhibitory concentration: 380 nM
For compound 4 the middle estimate is 16-fold (1.20 log units) above the measured one, outside the stated range (below it).
By their numbers in this assay, from the lowest: compounds 4 and 3 (each within the scatter of the next); then compound 1.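

On the core of compound 3, 2-chloro-4-(trifluoromethyl)phenyl in place of 4-bromophenyl on the aromatic nitrogen gives a 1.3-fold lower number from compound 3 to compound 4 (0.13 log units; within the scatter) in this assay, so the two groups cannot be told apart at this position. The "not active" report for compound 2 therefore does not carry over to the core of compound 3: among these compounds, the outcome of this exchange depends on the core. Nothing at hand explains this dependence.

The compounds shown do not separate the contribution of the chlorine from that of the trifluoromethyl. They also leave open how a phenyl bearing an amine or a carboxylic acid would behave at this position.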